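The source may report more compounds than this note shows. Statements on the series, on what has been measured and on what is new or still open speak of the compounds shown alone.

Three related compounds have been read in a functional assay on HepG2 cells (Homo sapiens) for cytotoxicity, read by spectrophotometry, with a stated time of 72 h; on this read-out higher numbers stand for weaker inhibition and lower numbers for stronger inhibition. Compound 1 `COc1ccc(-c2cccc(=O)n2-c2cc(OC)c(OC)c(OC)c2)cc1` gives < 10 nM, which is a limit of the assay and not a number. Compound 2 `COc1ccc(-n2c(-c3cc(OC)c(OC)c(OC)c3)cccc2=O)cc1O` gives 1220 nM, and compound 3 `COc1ccc(-n2c(-c3cc(OC)c(OC)c(OC)c3)cccc2=O)cc1OC` gives 4870 nM. Within the data shown here, compound 2 therefore holds the lower of the only two true numbers available, with the limit as the one remaining value.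

The next compound is compound 4 `COc1cc(-c2cccc(=O)n2-c2ccc(F)cc2)cc(OC)c1OC`, and the change leading to it is a whole group: 4-fluorophenyl in place of 3-hydroxy-4-methoxyphenyl on an aromatic nitrogen. In words, 4-fluorophenyl stands in place of 3-hydroxy-4-methoxyphenyl on an aromatic nitrogen. Among the measured compounds shown here, only one measured step bears on this group. It puts methyl in place of hydrogen on an oxygen on an aromatic ring, and it gives a 4.0-fold higher number from compound 2 to compound 3 (0.60 log units; beyond the scatter), a modest move beyond the scatter. Compound 3 thus loses the free hydroxy of compound 2 and reads weaker, and compound 4 lacks that hydroxy too. For the measured compounds named here, a single step is thin support, and the fluorine has no measured precedent here, so the forecast stays wide.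

In this assay the expected move is a 2.0-fold higher number from compound 2 to compound 4 (0.31 log units; beyond the scatter), a modest one towards a higher number and weaker inhibition. For compound 4 the estimate is 2500 nM, with an expected range from 500 nM to 10000 nM.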

Compound 4, half-maximal inhibitory concentration: > 100000 nM
Compound 4: a limit, no number; the forecaster's own chance of this, stated with the estimate: 10%; at least 40-fold (1.60 log units) between middle value and limit.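

In this assay, among these compounds, the group on the aromatic nitrogen proves far more sensitive to change than the single methyl step suggested: the whole-group swap gives an at least 81-fold higher number from compound 2 to compound 4 (1.91 log units; beyond the scatter), whereas capping the hydroxy gave only a 4.0-fold higher number from compound 2 to compound 3 (0.60 log units; beyond the scatter). The reading for compound 4 is a limit of the assay and not a number: the limit of > 100000 nM in this assay, at which 1 of the 4 values shown sits. The result therefore shows that keeping the 3-hydroxy-4-methoxyphenyl group matters much more here than the free hydroxy alone, since compound 3 keeps a measurable reading without that hydroxy, while the 4-fluorophenyl group, which counts 0 hydrogen-bond donors and 0 hydrogen-bond acceptors, goes with a far larger loss.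

The compounds shown leave open which part of the swap carries this loss, as the hydroxy and the methoxy leave and the fluorine enters in one move. They also leave open how a plain phenyl group, or an amine or a carboxylic acid in place of the hydroxy on the 3-hydroxy-4-methoxyphenyl group, would read on the same nitrogen.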